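The source may report more compounds than this note shows. Statements on the series, on what has been measured and on what is new or still open speak of the compounds shown alone.

Measured so far:
Compound 1 `Cc1nc(-c2ccccc2NCC2=NCCN2)no1` reaches in a functional assay for activation of Alpha-1D adrenergic receptor (Homo sapiens) (on this read-out higher numbers stand for an effect only at larger amounts of compound and lower numbers for an effect already at smaller amounts), only the assay limit of < 5020 nM.
Compound 2 `c1cnc(-c2ccccc2NCC2=NCCN2)nc1` gives in this assay 81.3 nM.

Going by the values given here, compound 2 therefore stands as the only compound of the pair with an actual number; the value of compound 1 is a limit and not a number, as the line the limit of < 5020 nM in this assay, at which 1 of the 2 values shown sits, records. Among the compounds with values here, the one step between measured compounds, a step that the limit leaves unreadable from compound 1 to compound 2, is consequently unreadable in size, and it says nothing about how far the pyrimidin-2-yl group itself carries the potency of compound 2.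

Compound 3 `CCO/N=C(\C)c1ccccc1NCC1=NCCN1` differs from compound 2 in one place: a group of 6 heavy atoms (4 carbon, 1 nitrogen, 1 oxygen; no ring) in place of a group of 6 heavy atoms (4 carbon, 2 nitrogen; one six-membered aromatic ring with 2 hetero atoms), on an aromatic carbon. Within the data shown here, no measured step bears on an exchange of this kind, because the only step available, a step that the limit leaves unreadable from compound 1 to compound 2, cannot be read. The expectation for compound 3 in this assay thus rests on the number for compound 2 alone, with wide uncertainty in both directions. Compound 3 is estimated at 250 nM, within a range from 40 nM to 1500 nM. This estimate corresponds to a step of a 3.1-fold higher number from compound 2 to compound 3 (0.49 log units; beyond the scatter) from compound 2 to compound 3, which is expected rather than known.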

Compound 3, half-maximal effective concentration: < 5020 nM
Compound 3 gave a limit, no number; the forecaster's own chance of this, stated with the estimate: 15%; the middle value does not contradict the limit.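

In this assay compound 3 gives < 5020 nM, which is a limit of the assay and not a number. No step from compound 2 or compound 1 to compound 3 can be read in size, as compound 1 and compound 3 both rest on one limit: the limit of < 5020 nM in this assay, at which 2 of the 3 values shown sit.

Left open is how much weaker than compound 2 compound 1 and compound 3 are, if they are weaker at all, and how those two compare with each other.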